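Replacing 1H-pyrrol-2-yl with 3,5-dimethylphenyl

The source may report more compounds than this note shows. Statements on the series, on what has been measured and on what is new or still open speak of the compounds shown alone.

In a functional assay on DU-145 cells (Homo sapiens) for inhibition, read by trypan blue exclusion, with a stated time of 96 h (a higher number here means a weaker inhibitor of growth, a lower number a stronger inhibitor of growth), compound 1 (`Cc1ccc(S/C(=C/c2ccc(Br)cc2)C(=O)c2ccc(Cl)cc2)cc1`) gives 25000 nM, compound 2 (`Cc1ccc(S/C(=C/c2sccc2C)C(=O)c2ccc(Cl)cc2)cc1`) gives 50000 nM, and compound 3 (`Cc1ccc(S/C(=C/c2ccc[nH]2)C(=O)c2ccc(Cl)cc2)cc1`) gives 10000 nM, the lowest of the three numbers. Compound 4 (`Cc1ccc(S/C(=C/c2cc(C)cc(C)c2)C(=O)c2ccc(Cl)cc2)cc1`) carries 3,5-dimethylphenyl in place of 1H-pyrrol-2-yl on a double-bonded chain carbon bound to a double-bonded chain carbon. The nearest guide is the swap of 4-bromophenyl for 1H-pyrrol-2-yl, a modest step of a 2.5-fold lower number from compound 1 to compound 3 (0.40 log units; beyond the scatter). Swapping 3-methylthiophen-2-yl for 1H-pyrrol-2-yl gave a 5.0-fold lower number from compound 2 to compound 3 (0.70 log units; beyond the scatter), also modest. Both suggest that losing 1H-pyrrol-2-yl will raise the number, so the expected change in this assay is a 2.5-fold higher number from compound 3 to compound 4 (0.40 log units; beyond the scatter). The estimate for compound 4 is 25000 nM, with an expected range of 10000 nM to 60000 nM.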

Compound 4, concentration for 50% growth inhibition: 50000 nM
Compound 4: the middle estimate sits 2.0-fold (0.30 log units) below what was measured; the range from low to high includes it.
By their numbers in this assay, from the lowest: compound 3; then compounds 1, 2 and 4 (each within the scatter of the next).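

In this assay there is a 5.0-fold higher number from compound 3 to compound 4 (0.70 log units; beyond the scatter), and this is the largest step seen with a carbon-only ring at this place. There is also no change at the digits printed from compound 2 to compound 4 (within the scatter) and a 2.0-fold higher number from compound 1 to compound 4 (0.30 log units; within the scatter), so 3,5-dimethylphenyl, 4-bromophenyl and 3-methylthiophen-2-yl cannot be told apart here, while 1H-pyrrol-2-yl, the only group shown with a hydrogen-bond donor, stands apart from all three. No supporting data explain this difference. On these data alone, whether that donor matters remains open, and 1-methyl-1H-pyrrol-2-yl, which has the same ring with a methyl on its nitrogen, would test it.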